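The source may hold more compounds than are shown below. What is called first, only, known or untested is meant among the compounds shown, and "the series" means these compounds.

Measured so far, with a physicochemical assay for lipophilicity, measured as octanol-water partition (a lower number here means a more polar compound, a higher number a more lipophilic compound), as the read-out:
- compound 1 `Cc1ccc(-c2c(C#N)[n+]([O-])c3cc(F)ccc3[n+]2[O-])cc1` gives 2.48
- compound 2 `Cc1ccc(-c2c(C#N)[n+]([O-])c3cc(Cl)ccc3[n+]2[O-])cc1` gives 2.6
- compound 3 `Cc1ccc(-c2c(C#N)[n+]([O-])c3cc(C(F)(F)F)ccc3[n+]2[O-])cc1` gives 2.95

Compound 2 stands second highest of the three, with a small gap on its lower side (a number 0.12 log units higher from compound 1 to compound 2 (within the scatter)) and a larger one on its upper side (a number 0.35 log units higher from compound 2 to compound 3 (beyond the scatter)) in the numbers.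

The next compound, compound 4 `COc1ccc(-c2c(C#N)[n+]([O-])c3cc(Cl)ccc3[n+]2[O-])cc1`, differs from compound 2 in one place: methoxy in place of methyl on an aromatic carbon, para to a large group (methoxy in place of methyl on an aromatic carbon). Going by the values given here, none of the measured steps touches that place. Among the compounds with values here, all three exchange fluoro, chloro and trifluoromethyl while the methyl stays, so they offer a scale of size and no direct precedent. The largest of them is a number 0.47 log units higher from compound 1 to compound 3 (beyond the scatter) and it is still only modest. Within the data shown here, the series holds no measured example of methyl going to methoxy, so the direction rests on the structural change alone and is uncertain. A modest move to a lower number is expected, of about the size of the measured modest steps: a number 0.35 log units lower from compound 2 to compound 4 (beyond the scatter) is the estimated step. Estimated for compound 4 is 2.25, expected to fall from 1.9 to 2.6 on measurement.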

Compound 4, partition coefficient: 2.09
For compound 4 the middle estimate is 0.16 log units above the measured one; low and high end bracket the measured number.
By their numbers in this assay, from the lowest: compound 4; then compounds 1 and 2 (each within the scatter of the next); then compound 3.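

In this assay, the position para to a large group, held as methyl through all the earlier exchanges, now proves able to shift the read-out: a number 0.51 log units lower from compound 2 to compound 4 (beyond the scatter). This step is modest, like a number 0.47 log units higher from compound 1 to compound 3 (beyond the scatter) and a number 0.35 log units higher from compound 2 to compound 3 (beyond the scatter), but it runs the other way, so the series now has a change that lowers the number as well as changes that raise it, and the place where this happens is a different one from the site of the fluoro, chloro and trifluoromethyl exchanges. Nothing available explains the drop on going from methyl to methoxy, which brings in an oxygen and a hydrogen-bond acceptor.

On these data alone, the step rests on a single pair with chloro on the core, so whether methoxy in place of methyl gives a step of like size and direction with fluoro or trifluoromethyl there stays open. As far as these compounds go, how an amine, a carboxylic acid or a longer chain such as ethoxy would read at this same place in this assay also stays open, as does whether the oxygen of methoxy alone sets the direction.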